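A Bromine-for-Methyl Swap on the Amide of Compound 1

The source may hold more compounds than are shown below. What is called first, only, known or untested is meant among the compounds shown, and "the series" means these compounds.

Measured compounds:
compound 1, `CCN1CCN(c2cc(C)c3cc(NC(=O)c4ccc(C)cc4)ccc3n2)CC1`: 6740 nM
compound 2, `Cc1cc(N(C)C)nc2ccc(NC(=O)c3ccc(Cl)c(Cl)c3)cc12`: 33300 nM

Both numbers come from a functional assay on MCF7 cells (Homo sapiens) for antiproliferative activity, read by MTT assay, with a stated time of 72 h; on this read-out lower numbers stand for stronger inhibition and higher numbers for weaker inhibition. Compound 1 gives 6740 nM, the lower of the two values, and compound 2 gives 33300 nM, a gap that lies beyond the usual scatter. Compound 2 differs from compound 1 in more than one place, so nothing here isolates the effect of the group on the carbonyl carbon alone.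

Compound 3, `CCN1CCN(c2cc(C)c3cc(NC(=O)c4cccc(Br)c4)ccc3n2)CC1`, keeps the core and the amide of compound 1 and changes only the aryl group on the carbonyl carbon: 3-bromophenyl in place of 4-methylphenyl on a carbonyl carbon. The groups that leave and enter are of the same size and neither adds a donor or an acceptor. Going by the values given here, no measured pair shows what such a swap does in this assay, so the step is expected to be small, with no clear direction, and most likely inside the scatter. The step from compound 1 to compound 3 is estimated at a 1.2-fold higher number from compound 1 to compound 3 (0.07 log units; within the scatter). Compound 3 is therefore expected to give about 8000 nM, within a range of 2500 nM to 25000 nM.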

Compound 3, half-maximal inhibitory concentration: 11600 nM
Estimate against measurement, compound 3: 1.5-fold (0.16 log units) below; the range from low to high includes it.
By their numbers in this assay, from the lowest: compounds 1 and 3 (each within the scatter of the next); then compound 2.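

Going by these compounds alone, this is the first pair that differs only in the group on the carbonyl carbon, and in this assay the swap gives a 1.7-fold higher number from compound 1 to compound 3 (0.24 log units; within the scatter). A step of this size means that compound 1 and compound 3 cannot be told apart in this assay, so here 3-bromophenyl and 4-methylphenyl serve equally well on the amide of the shared core. The names of the two groups show that the swap changes both the atom on the ring and its numbered place, and this single pair cannot separate those two changes; nothing measured on these compounds offers a cause for the result either.

Still open, as far as these compounds go, is whether 4-bromophenyl or 3-methylphenyl would give a value in line with these two, and whether a ring carrying an amine or a carboxylic acid, or a longer chain in place of the ring, would move the number beyond the scatter. Compound 2 differs from compound 1 and compound 3 in more than one place, so what sets its value apart also remains unresolved.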